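Compound 3: pyridin-2-yl in place of phenyl

A few compounds are considered here, and "the series" means these few. Any claim that something is new, unique, unknown or untested is made for them only; others in the source may bear on it.

In a functional assay on A2780 cells (Homo sapiens) for cytotoxicity, read by MTT assay, with a stated time of 48 h (a higher number here means a weaker inhibitor, a lower number a stronger inhibitor), compound 1 (`CN(C)CCCCN(C)C1=Nc2ccccc2C(CC(=O)NCc2ccccc2)N1c1ccc(-c2ccccc2)cc1`) gives 1650 nM and compound 2 (`CN(C)CCN1CCN(C2=Nc3ccccc3C(CC(=O)NCc3ccccc3)N2c2ccc(-c3ccccc3)cc2)CC1`) gives 1390 nM, so compound 2 stands level with compound 1. Among the measured compounds shown here, the one measured step, a 1.2-fold lower number from compound 1 to compound 2 (0.07 log units; within the scatter), concerns the group on the carbon with a double bond to nitrogen, not the amide end. Compound 3 (`CN(C)CCN1CCN(C2=Nc3ccccc3C(CC(=O)NCc3ccccn3)N2c2ccc(-c3ccccc3)cc2)CC1`) carries pyridin-2-yl in place of phenyl on a saturated chain carbon bound to an amide-type nitrogen. For the measured compounds named here, no measured step covers this place, so the data offer no ground for a shift. The expected result is a 1.2-fold higher number from compound 2 to compound 3 (0.06 log units; within the scatter), inside the usual scatter. The estimate for compound 3 is 1600 nM, with an expected range of 700 nM to 3600 nM.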

Compound 3, half-maximal inhibitory concentration: 4860 nM
Beside the measured number, compound 3's estimate is 3.0-fold (0.48 log units) below it; the whole stated range lies below it.
By their numbers in this assay, from the lowest: compounds 2 and 1 (each within the scatter of the next); then compound 3.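

Among the compounds shown here, the amide end of the series responds in this assay: pyridin-2-yl in place of phenyl on a saturated chain carbon bound to an amide-type nitrogen gives a 3.5-fold higher number from compound 2 to compound 3 (0.54 log units; beyond the scatter) while the only earlier step, at the carbon with a double bond to nitrogen, stayed within the scatter. The change keeps the heavy-atom count and adds one hydrogen-bond acceptor. Nothing available accounts for the shift. Open, as far as these compounds go, is how cyclohexyl or pyrimidinyl would read in place of phenyl. Also open, from the compounds shown here alone, is whether the shift carries over to the (4-(dimethylamino)butyl)(methyl)amino series.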